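Acetoxy for aryl ketone in a chromene series

The source may report more compounds than this note shows. Statements on the series, on what has been measured and on what is new or still open speak of the compounds shown alone.

For the measured compounds named here, in a functional assay (trachea) with Rattus norvegicus as the target (on this read-out higher numbers stand for higher potency (the scale is a negative logarithm) and lower numbers for lower potency), compound 2 `Cc1ccccc1C(=O)c1ccc2c(c1)C(n1ccccc1=O)=CC(C)(C)O2` gives 6.25, the higher of the two numbers known; compound 1 `CC1(C)C=C(n2ccccc2=O)c2cc(C(=O)c3cccs3)ccc2O1` gives 5.84. Going by the values given here, the one step known, a number 0.41 log units higher from compound 1 to compound 2 (beyond the scatter), swaps one aryl group for another on the carbonyl, whereas compound 3 `CC(=O)Oc1ccc2c(c1)C(n1ccccc1=O)=CC(C)(C)O2` carries acetoxy in place of (2-methylphenyl)carbonyl on an aromatic carbon. Among the compounds with values here, no measured step bears directly on removing the whole aryl ketone, so any expectation is uncertain; with the larger group gone, the step is expected to be a number 0.95 log units lower from compound 2 to compound 3 (beyond the scatter). Compound 3 is thus estimated at 5.3, in a range from 4.5 to 6.1.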

Compound 3, logarithm of the reciprocal of the active concentration, log(1/C): 4.97
The estimate for compound 3 lay 0.33 log units above the measured number, and the stated range covers the measured number.
By their numbers in this assay, from the lowest: compound 3; then compound 1; then compound 2.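

In this assay, this position proves sensitive to more than the choice of aryl group: with acetoxy in place of the (2-methylphenyl)carbonyl group, the result is a number 1.28 log units lower from compound 2 to compound 3 (beyond the scatter), and with acetoxy in place of the (thiophen-2-yl)carbonyl group, it is a number 0.87 log units lower from compound 1 to compound 3 (beyond the scatter). Both aryl ketones therefore stand above the acetoxy compound, each by a step beyond the scatter. Nothing available here explains this difference. The compounds shown leave open whether the aromatic ring or the carbonyl matters more at this position. A simple methyl ketone or a benzyl ether in the same place would help to separate the two.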